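Compound 1 and its bromine positional isomer, compound 4

The source may report more compounds than this note shows. Statements on the series, on what has been measured and on what is new or still open speak of the compounds shown alone.

Three analogues sharing one core were tested in a functional assay on HCT-116 cells (Homo sapiens) for antiproliferative activity, read by MTT assay, with a stated time of 24 h; on this read-out higher numbers stand for weaker inhibition and lower numbers for stronger inhibition. Compound 1 `COc1cc(OC)c(-c2coc3cc(OCc4ccc(Br)cc4)ccc3c2=O)cc1OC` gives 1980 nM, the lowest of the two numbers shown. Compound 3 `COc1cc(OC)c(-c2coc3cc(OCc4ccc(Cl)cc4)ccc3c2=O)cc1OC` gives 4450 nM, which is a 2.2-fold higher number from compound 1 to compound 3 (0.35 log units; beyond the scatter). For compound 2 `COc1cc(OC)c(-c2coc3cc(OCc4ccc([N+](=O)[O-])cc4)ccc3c2=O)cc1OC` the assay reports only a limit, > 10000 nM. Compound 4 `COc1cc(OC)c(-c2coc3cc(OCc4cccc(Br)c4)ccc3c2=O)cc1OC` differs from compound 1 by 3-bromophenyl in place of 4-bromophenyl on a saturated chain carbon bound to an oxygen on an aromatic ring. The measured steps exchange the substituent on that ring while keeping its place, namely an at least 5.0-fold higher number from compound 1 to compound 2 (0.70 log units; beyond the scatter) and an at least 2.2-fold lower number from compound 2 to compound 3 (0.35 log units; beyond the scatter), so neither bears directly on moving the bromine. Among the compounds with values here, with no step covering such a shift, the change is expected to read a 1.3-fold higher number from compound 1 to compound 4 (0.10 log units; within the scatter), within the scatter. Compound 4 is therefore estimated at 2500 nM, between 1000 nM and 6500 nM.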

Compound 4, half-maximal inhibitory concentration: 1200 nM
Estimate against measurement, compound 4: 2.1-fold (0.32 log units) above, and the stated range covers the measured number.
By their numbers in this assay, from the lowest: compounds 4 and 1 (each within the scatter of the next); then compound 3. At a limit, above all of these: compound 2.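

In this assay the shift from 4-bromophenyl to 3-bromophenyl on this saturated chain carbon stays within the scatter (a 1.7-fold lower number from compound 1 to compound 4 (0.22 log units; within the scatter)), so among these two compounds the place of the bromine on the ring does not separate them. Compound 4 does stand apart from the chloro and nitro analogues (a 3.7-fold lower number from compound 3 to compound 4 (0.57 log units; beyond the scatter); an at least 8.3-fold lower number from compound 2 to compound 4 (0.92 log units; beyond the scatter)). The second of these steps starts from a limit and not from a number: the limit of > 10000 nM in this assay, at which 1 of the 4 values shown sits.

The compounds shown leave open how chloro or nitro would read from the 3-position, and whether an amine or a carboxylic acid on this ring would keep the level of compound 1 and compound 4.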